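A Chloro Group on a Weakly Cytotoxic Series

The source may hold more compounds than are shown below. What is called first, only, known or untested is meant among the compounds shown, and "the series" means these compounds.

In a functional assay on MCF7 cells (Homo sapiens) for cytotoxicity, read by MTT assay, with a stated time of 48 h (a lower number here means a stronger inhibitor, a higher number a weaker inhibitor), compound 1 `COc1cc(C#N)ccc1OCc1nnc(-c2ccc(C)cc2)o1` gives 27100 nM and compound 2 `N#Cc1ccc(OCc2nnc(-c3ccc(Cl)cc3)o2)cc1F` gives 48300 nM, two values that lie within the usual scatter of each other. Compound 3 `c1ccc(-c2nnc(COc3ccc(-c4nnco4)cc3)o2)cc1` stands at > 50000 nM in this assay and that entry is a limit of the assay, not a number. It therefore marks no exact starting point for the next comparison.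

Compound 4 `Clc1ccc(-c2nnc(COc3ccc(-c4nnco4)cc3)o2)cc1` departs from compound 3 in one place: chloro in place of hydrogen on an aromatic carbon, which turns phenyl into 4-chlorophenyl. Among the measured compounds shown here, no measured pair isolates this change, so its size cannot be read directly from the data. Compound 2 also carries a 4-chlorophenyl group and gives 48300 nM, though the rest of its structure differs, so it offers only a loose guide. On that basis a small move toward stronger inhibition is expected in this assay, and a step no larger than the scatter would be no surprise. The expected step is an at least 1.3-fold lower number from compound 3 to compound 4 (0.11 log units; that floor lies within the scatter), and the measurement may yet return only a limit. For compound 4 the estimate is 38000 nM, with an expected range from 14000 nM to 50000 nM.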

Compound 4, half-maximal inhibitory concentration: 45200 nM
Beside the measured number, compound 4's estimate is 1.2-fold (0.08 log units) below it; measured number inside the range.
By their numbers in this assay, from the lowest: compounds 1, 4 and 2 (each within the scatter of the next). At a limit, above all of these: compound 3.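

Compound 3 stands at > 50000 nM in this assay, which is a limit of the assay and not a number. Chloro in place of hydrogen on an aromatic carbon, para to a large group, turns phenyl into 4-chlorophenyl and gives an at least 1.1-fold lower number from compound 3 to compound 4 (0.04 log units; that floor lies within the scatter), the only step in the series that isolates this change, and compound 4 now reads as a number at this position, so the step has a floor but no measured size. The true size of the step cannot be read from this pair, and the floor alone does not show a change beyond the scatter, because one end of the pair sits at the limit: the limit of > 50000 nM in this assay, at which 1 of the 4 values shown sits.

The compounds shown leave open how an amine or a carboxylic acid would read in place of chloro on this same aromatic carbon in this assay, and whether any such group would give a step beyond the scatter. They also leave open whether chloro in place of hydrogen gives a comparable step on another core, since compound 2 carries the same 4-chlorophenyl group but differs from compound 4 in more than one place.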